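Swapping an amine for an ether on a pyridine core

The source may hold more compounds than are shown below. What is called first, only, known or untested is meant among the compounds shown, and "the series" means these compounds.

Measured compounds:
compound 1 `CC1CCN(c2nc(C(F)(F)F)ccc2CNC(=O)Nc2cccc3ccc(=O)[nH]c23)CC1` — "not active" (no number reported)
compound 2 `CC1CCN(c2nc(C(F)(F)F)ccc2CNC(=O)Nc2cccc3cc[nH]c(=O)c23)CC1` — "not active" (no number reported)
compound 3 `O=C(NCc1ccc(C(F)(F)F)nc1N1CCCCC1)Nc1cccc2c(=O)[nH]ccc12` — 13.2 nM

In an assay on CHO cells for agonist activity at transient receptor potential cation channel subfamily V member 1 (Homo sapiens) (a higher number here means that more compound is needed for the effect, a lower number that less compound is needed), compound 3 gives 13.2 nM, the only numerical result among the three. For the measured compounds named here, compound 1 is recorded as "not active" (no number reported), and compound 2 likewise as "not active" (no number reported); neither carries a number, so no step between them and compound 3 can be counted.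

Compound 4 `O=C(NCc1ccc(C(F)(F)F)nc1OCC1CCCC1)Nc1cccc2c(=O)[nH]ccc12` differs from compound 3 in a single place: cyclopentylmethoxy in place of piperidin-1-yl on an aromatic carbon, next to the ring nitrogen. No comparable exchange between two measured compounds is available, so the size of the step rests on the change itself.

For compound 4 a small loss in this assay is expected, a step of a 1.7-fold higher number from compound 3 to compound 4 (0.22 log units; within the scatter) that may not exceed the scatter of repeat measurements. The estimated half-maximal effective concentration of compound 4 is 22 nM, within a range from 5 nM to 90 nM.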

Compound 4, half-maximal effective concentration: 15.5 nM
Compound 4: the middle estimate sits 1.4-fold (0.15 log units) above what was measured; measured number inside the range.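

In this assay, cyclopentylmethoxy in place of piperidin-1-yl on the aromatic carbon next to the ring nitrogen comes with a 1.2-fold higher number from compound 3 to compound 4 (0.07 log units; within the scatter), so the two compounds cannot be told apart in this read-out. For the compounds shown here, this pair is the first readable comparison in the set, and it shows that this position takes an oxygen-linked five-membered carbon ring as readily as a nitrogen-linked six-membered ring, with no loss beyond the scatter. Nothing measured here explains why the exchange is tolerated.

Going by these compounds, what a plain methoxy group or a dimethylamino group would do at this carbon stays open, so it is unclear whether a ring is needed here at all. Also open, on these data alone, is how a longer chain, such as cyclopentylethoxy, would fare at the same place.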